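The source may report more compounds than this note shows. Statements on the series, on what has been measured and on what is new or still open speak of the compounds shown alone.

Two compounds share a core that carries a sulfamate on a fused bicyclic ring joined through an amide to a substituted benzene. Compound 1 `CCN(Cc1ccccc1)c1cccc(C(=O)N2CCc3ccc(OS(N)(=O)=O)cc3C2)c1` and compound 2 `CC(C)CCN(CCC(C)C)c1ccc(C(=O)N2CCc3ccc(OS(N)(=O)=O)cc3C2)cc1` were both tested in an assay on HEK293 cells for inhibition of Steryl-sulfatase (Homo sapiens), tested at 0.1 uM; a higher number here means a stronger effect of the compound at the concentration tested, a lower number a weaker effect. In this assay compound 1 gives 17.3%, while compound 2 gives 47%, the higher of the two numbers and a difference from compound 1 that lies beyond the usual scatter.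

Compound 3 `CCN(Cc1ccc(F)cc1)c1ccc(C(=O)N2CCc3ccc(OS(N)(=O)=O)cc3C2)cc1` has not yet been measured. It differs from compound 2 in a single place: ethyl(4-fluorobenzyl)amino in place of diisopentylamino on an aromatic carbon. Among the compounds with values here, no measured pair describes this change directly, so the only guide is that compound 1, which also carries an ethyl(benzyl)amino group, gives 17.3%. On that basis compound 3 is expected to fall below compound 2, with an estimated step of a number 22 percentage points lower from compound 2 to compound 3 (beyond the scatter) that would exceed the scatter. Compound 3 is therefore estimated at 25%, within a range from 10% to 42%.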

Compound 3, a percentage reported as inhibition, at one concentration (the size of the read-out at that concentration, not a potency): 69.1%
For compound 3 the middle estimate is 44.1 percentage points below the measured one; measured number above the stated range.
By their numbers in this assay, from the lowest: compound 1; then compound 2; then compound 3.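

In this assay the exchange of diisopentylamino for ethyl(4-fluorobenzyl)amino on an aromatic carbon, para to a large group, brings a number 22.1 percentage points higher from compound 2 to compound 3 (beyond the scatter) so this position accepts a group carrying a six-membered aromatic ring of carbon only and gains from it. Both groups hold 11 heavy atoms, add no hydrogen-bond donor and have no net charge, so the rise comes with no change in those counts. Nothing at hand shows what lies behind this step.

The compounds shown leave open whether the fluorine plays any part, since an unsubstituted benzyl group or a 4-chlorobenzyl group at this position does not appear among them. They also leave open how the read-out responds when the ethyl group on the nitrogen gives way to a methyl group or a longer chain such as propyl.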